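This account rests on a few compounds, and the source may have more. Where it says the series, first, only, none or still open, it means among the compounds named here.

Compound 1 `Cc1ccc(S(=O)(=O)Nc2ccc3oc(-c4ccccc4)nc3c2)cc1` was tested in an assay on cells for inhibition of HSP60/HSP10 (Homo sapiens), with a stated time of 60 min (on this read-out higher numbers stand for weaker inhibition and lower numbers for stronger inhibition), and there compound 1 gives > 100000 nM, which is a limit of the measurement rather than a number. A second member of the series, compound 2 `O=S(=O)(Nc1ccc2oc(-c3ccccc3)nc2c1)c1ccc(Cl)c(C(F)(F)F)c1`, was tested in the same way, and compound 2 gives > 100000 nM, again a limit rather than a number. Taken together this is the limit of > 100000 nM in this assay, at which 2 of the 2 values shown sit. Compound 1 therefore stands at the edge of what the measurement can report, with no number that would place it higher or lower than its neighbour.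

Compound 3 `O=S(=O)(Nc1ccc2oc(-c3ccccc3)nc2c1)c1cccs1` has not yet been measured. It differs from compound 1 by thiophen-2-yl in place of 4-methylphenyl on a sulfonyl sulfur. With both known results at the limit, no step beyond the usual scatter is expected in this assay from this change, in either direction; the expected step is a step that the limit leaves unreadable from compound 1 to compound 3. Compound 3 is estimated to give 200000 nM, within a range from 60000 nM to 700000 nM, and most likely to be reported again as a limit.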

Compound 3, half-maximal inhibitory concentration: 90000 nM
Compound 3: the middle estimate sits 2.2-fold (0.35 log units) above what was measured; the measured number falls inside the stated range.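

Of the compounds shown, compound 3 is the first to give a number rather than a limit in this assay, so thiophen-2-yl on the sulfonyl sulfur at least keeps the result within what the measurement can report. Read as a step, this is an at least 1.1-fold lower number from compound 1 to compound 3 (0.04 log units; that floor lies within the scatter), which does not show a gain beyond the usual scatter, though the true step could be larger. The step can be given only as a floor, because compound 1 has a limit and not a number: the limit of > 100000 nM in this assay, at which 2 of the 3 values shown sit.

Going by these compounds, it remains open whether an aromatic ring carrying an amine or a carboxylic acid, or a plain alkyl chain, on the sulfonyl sulfur would move the number further. The compounds shown also leave open how changes elsewhere on the shared core would affect this read-out.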